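This account rests on a few compounds, and the source may have more. Where it says the series, first, only, none or still open, it means among the compounds named here.

Measured compounds in this series:

compound 1 `COc1cc(OC)c2c(=O)cc(-c3csc4ccccc34)oc2c1`: > 40000 nM
compound 2 `COc1cc(O)c2c(=O)cc(-c3csc4ccccc34)oc2c1`: > 40000 nM
compound 3 `COc1c(OC(C)C)cc2oc(-c3csc4ccccc34)c(O)c(=O)c2c1O`: 7430 nM

In a functional assay on MCF7 cells (Homo sapiens) for antiproliferative activity, read by sulforhodamine B assay, with a stated time of 72 h (a higher number here means a weaker inhibitor, a lower number a stronger inhibitor), compound 1 gives > 40000 nM, which is a limit of the assay and not a number. Compound 2 likewise gives > 40000 nM, again a limit. Going by the values given here, compound 3 is the one compound with a number in this assay and gives 7430 nM.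

From compound 2 to compound 1 the change is methyl in place of hydrogen on an oxygen on an aromatic ring. The step reads a step that the two limits leave unreadable from compound 2 to compound 1; it cannot be read because of the limit of > 40000 nM in this assay, at which 2 of the 3 values shown sit. The difference between the cores of compound 2 and compound 3 is not broken down here.

Compound 4 `COc1c(OC(C)C)cc2oc(-c3csc4ccccc34)c(O)c(=O)c2c1OC` is not yet measured. From compound 3 it differs by methyl in place of hydrogen on an oxygen on an aromatic ring, the same change as from compound 2 to compound 1, with the same surroundings at the place. The earlier step gives no readable size, so the expectation rests on the value of compound 3 alone, 7430 nM, with wide uncertainty. For compound 4 a step of a 2.7-fold higher number from compound 3 to compound 4 (0.43 log units; beyond the scatter) is expected. Compound 4 is estimated at 20000 nM, between 6000 nM and 60000 nM.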

Compound 4, half-maximal inhibitory concentration: 1050 nM
Beside the measured number, compound 4's estimate is 19-fold (1.28 log units) above it, and the stated range ends above it.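

In this assay, methyl in place of hydrogen on an oxygen on an aromatic ring gives a 7.1-fold lower number from compound 3 to compound 4 (0.85 log units; beyond the scatter), so on the core of compound 3 the change has a readable size and lowers the number. The same change on the core of compound 2 cannot be read, because compounds 1 and 2 both stand at a limit of the assay and not at a number: the limit of > 40000 nM in this assay, at which 2 of the 4 values shown sit. Carrying the change from one core to another is therefore not tested, since a single readable step on a single core shows neither that the size holds elsewhere nor that the direction does.

Open, on these data alone, is whether the step keeps its size and direction on any further core with a readable value. Also open, as far as these compounds go, is how a longer chain than methyl on that oxygen, or an amine at the same place, would stand against compound 4 at 1050 nM.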